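Working notes: from compound 2 to compound 3

A few compounds are considered here, and "the series" means these few. Any claim that something is new, unique, unknown or untested is made for them only; others in the source may bear on it.

Of the compounds shown here, two have numbers so far, compound 1 `O=C(NO)c1ccc(CN2C(=O)/C(=C3\Nc4ccccc4\C3=N/O)c3cc(F)ccc32)cc1` and compound 2 `COc1ccc2c(c1)/C(=C1/Nc3ccccc3/C1=N\O)C(=O)N2Cc1ccc(/C=C/C(=O)NO)cc1`. Among the compounds with values here, in a functional assay on NCI-H23 cells (Homo sapiens) for cytotoxicity, read by colorimetric assay (on this read-out higher numbers stand for weaker inhibition and lower numbers for stronger inhibition), compound 1 gives 30 nM and compound 2 gives 50 nM, so compound 2 stands within the scatter of the only other measured value. Compound 3 `COc1ccc2c(c1)/C(=C1/Nc3ccccc3/C1=N\O)C(=O)N2Cc1ccc(C(=O)NO)cc1` is still unmeasured. It comes from compound 2 by one change, hydroxycarbamoyl in place of 2-(hydroxycarbamoyl)ethenyl on an aromatic carbon, para to a large group. Within the data shown here, no measured pair isolates this change, so the data give no direct size for it. Among the measured compounds shown here, the only guide is the narrow spread of the two values, compound 1 at 30 nM and compound 2 at 50 nM. The estimated step of a 1.3-fold lower number from compound 2 to compound 3 (0.10 log units; within the scatter) is expected to stay within the scatter in this assay, with no firm direction. For compound 3 the estimated value is 40 nM, with an expected range of 15 nM to 120 nM.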

Compound 3, half-maximal inhibitory concentration: 90 nM
For compound 3 the middle estimate is 2.3-fold (0.35 log units) below the measured one; measured number inside the range.
By their numbers in this assay, from the lowest: compounds 1, 2 and 3 (each within the scatter of the next, the first and the last beyond it).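

In this assay, hydroxycarbamoyl in place of 2-(hydroxycarbamoyl)ethenyl para to a large group gives a 1.8-fold higher number from compound 2 to compound 3 (0.26 log units; within the scatter) and so, in this one direct pair with methoxy held fixed, the two groups cannot be told apart at this position. Within the data shown here, with hydroxycarbamoyl held fixed, methoxy in place of fluoro on an aromatic carbon gives a 3.0-fold higher number from compound 1 to compound 3 (0.48 log units; beyond the scatter) as the only single-place step beyond the scatter, and it is modest. No supporting data bear on the origin of either step.

Going by these compounds, compounds 1 and 2 differ in two places, so it stays open whether the methoxy and fluoro comparison holds when 2-(hydroxycarbamoyl)ethenyl is present. The compounds shown also leave open how a carboxylic acid in place of hydroxycarbamoyl, or a longer chain carrying it, would read here.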